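Flipping One Ring Carbon of a Small Amine

The source may hold more compounds than are shown below. What is called first, only, known or untested is meant among the compounds shown, and "the series" means these compounds.

Of the compounds shown here, three have so far been tested in an assay on isolated protein for inhibition of alpha-galactosidase A (Homo sapiens), read by fluorescence, tested at 100 uM; on this read-out lower numbers stand for less inhibition and higher numbers for more inhibition at the one concentration tested (going by the name of the read-out). Compound 1 `O=C(CCC1CCCC1)NC[C@H]1NC[C@H](O)[C@@H](O)[C@H]1O` gives 99%, and compound 2 `O=C(CCCCC1CCCCC1)NC[C@H]1NC[C@H](O)[C@@H](O)[C@H]1O` gives 99%. Compound 3 `NC[C@@H]1NC[C@H](O)[C@@H](O)[C@H]1O` gives 30%, the lowest of the three numbers, separated from each of the other two by a gap beyond the usual scatter. The next compound, compound 4 `NC[C@H]1NC[C@H](O)[C@@H](O)[C@H]1O`, has not yet been measured. Compared with compound 3: the two compounds have the same atoms and bonds and differ only in configuration as drawn: 1 of 4 stereo elements differ; a stereocentre at a saturated ring carbon is drawn S in compound 3 and R in compound 4. For the measured compounds named here, no pair of measured compounds shows the effect of such a change on its own, so the size of the step is open; a shift of moderate size in either direction, or none beyond the scatter, would fit what is known. Compound 4 is estimated at 50%, with a range from 15% to 90%, which means an expected step of a number 20 percentage points higher from compound 3 to compound 4 (beyond the scatter).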

Compound 4, a percentage reported as inhibition, at one concentration (the size of the read-out at that concentration, not a potency): 99%
Compound 4: middle estimate off by 49 percentage points, on the low side; the whole stated range lies below it.
By their numbers in this assay, from the lowest: compound 3; then compounds 1, 2 and 4 (each within the scatter of the next).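

In this assay, the configuration at this one saturated ring carbon matters a great deal by itself: going from the S to the R drawing gives a number 69 percentage points higher from compound 3 to compound 4 (beyond the scatter). That step can belong only to this stereocentre, since nothing else separates the pair: the fact that compounds 3 and 4 differ only in the configuration as drawn. Compound 4 also stands within the scatter of compounds 1 and 2 without their amide side chains.

Going by these compounds, whether the S drawing would matter as much in a compound carrying such an amide remains open. So does how a sulfonamide or a carboxylic acid in that place would read.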